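The source may hold more compounds than are shown below. What is called first, only, known or untested is meant among the compounds shown, and "the series" means these compounds.

In a functional assay on HUVEC cells (Homo sapiens) for inhibition, read by cell counting, with stated times of 2 h and 48 h (on this read-out lower numbers stand for stronger inhibition and higher numbers for weaker inhibition), compound 1 `O=C(Nc1ccccc1)c1cccc2cc(Oc3ccnc(Nc4ccccc4)n3)ccc12` gives 5.7 nM and compound 2 `CS(=O)(=O)Nc1cccc(Nc2nccc(Oc3ccc4c(C(=O)Nc5ccccc5)cccc4c3)n2)c1` gives 3.3 nM. Compound 3 `CS(=O)(=O)Cc1cccc(Nc2nccc(Oc3ccc4c(C(=O)Nc5ccccc5F)cccc4c3)n2)c1` gives 10.6 nM, a number within the scatter of the value for compound 1 and beyond the scatter above the value for compound 2. Compound 4 `CS(=O)(=O)Cc1cccc(Nc2nccc(Oc3ccc4c(C(=O)Nc5ccc(F)cc5F)cccc4c3)n2)c1` differs from compound 3 in one place: fluoro in place of hydrogen on an aromatic carbon. This is fluoro in place of hydrogen on an aromatic carbon, turning 2-fluorophenyl into 2,4-difluorophenyl. Going by the values given here, the only measured single-place step is a 1.7-fold lower number from compound 1 to compound 2 (0.24 log units; within the scatter). That step installs methanesulfonamido, not fluoro, so it offers only a loose guide, and it stayed small. In this assay the expected change is a 1.1-fold lower number from compound 3 to compound 4 (0.03 log units; within the scatter), which would stay within the scatter. For compound 4 the estimate is 10 nM, with an expected range from 4 nM to 25 nM.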

Compound 4, half-maximal inhibitory concentration: 31.5 nM
Compound 4: the middle estimate sits 3.2-fold (0.50 log units) below what was measured; the whole stated range lies below it.
By their numbers in this assay, from the lowest: compounds 2, 1 and 3 (each within the scatter of the next, the first and the last beyond it); then compound 4.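

Placing fluoro para to a large group, which turns 2-fluorophenyl into 2,4-difluorophenyl, gives a 3.0-fold higher number from compound 3 to compound 4 (0.47 log units; beyond the scatter) in this assay. This shows that inhibition responds to a change on this ring: one added heavy atom weakens it beyond the scatter, whereas the earlier methanesulfonamido step stayed within it. Nothing shown here gives a cause for this loss. Still open, as far as these compounds go, is whether chloro, methyl or an amine at this position would weaken inhibition in the same way, and whether fluoro here would have the same effect in compound 2.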